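The source may hold more compounds than are shown below. What is called first, only, known or untested is meant among the compounds shown, and "the series" means these compounds.

Three compounds share one core and differ only in the methyl groups on the ring attached to the carbonyl. Compound 1 `Cc1cccc(C(=O)c2c(OCC(=O)Nc3ccc(S(N)(=O)=O)cc3C)ccc3ccccc23)c1` gives 40400 nM in an ADME assay on C8166 cells (Homo sapiens) for cytotoxicity, read by colorimetric assay and MTT assay; on this read-out higher numbers stand for lower toxicity in this test and lower numbers for higher toxicity in this test. Compound 2 `Cc1ccc(C)c(C(=O)c2c(OCC(=O)Nc3ccc(S(N)(=O)=O)cc3C)ccc3ccccc23)c1` gives 47500 nM in this assay, and compound 3 `Cc1ccc(C(=O)c2c(OCC(=O)Nc3ccc(S(N)(=O)=O)cc3C)ccc3ccccc23)cc1C` gives 33000 nM. All three numbers lie close together: the change from compound 1 to compound 2 is a 1.2-fold higher number from compound 1 to compound 2 (0.07 log units; within the scatter), from compound 1 to compound 3 it is a 1.2-fold lower number from compound 1 to compound 3 (0.09 log units; within the scatter), and from compound 2 to compound 3 it is a 1.4-fold lower number from compound 2 to compound 3 (0.16 log units; within the scatter). Compound 3 therefore stands with the other two, none set apart beyond the scatter.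

Compound 4 `Cc1ccc(C(=O)c2c(OCC(=O)Nc3ccc(S(N)(=O)=O)cc3C)ccc3cc(C#N)ccc23)cc1C` differs from compound 3 by cyano in place of hydrogen on an aromatic carbon. Going by the values given here, no measured step involves a cyano group, and the steps that are known, all methyl changes on an aromatic carbon, stayed within the scatter. On that basis the step from compound 3 to compound 4 is expected to be no change at the digits printed from compound 3 to compound 4 (within the scatter), with no real change in this assay. Compound 4 is thus estimated at 33000 nM, in a range from 15000 nM to 70000 nM.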

Compound 4, half-maximal cytotoxic concentration: > 379000 nM
Compound 4: only a limit was reported (the forecaster's own chance of this, stated with the estimate: 15%); middle value at least 11-fold (1.06 log units) from the limit.
By their numbers in this assay, from the lowest: compounds 3, 1 and 2 (each within the scatter of the next). At a limit, above all of these: compound 4.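

The methyl changes on the ring attached to the carbonyl stayed within the scatter, but this change sits elsewhere, on an aromatic carbon of a six-membered aromatic ring of carbon only, part of a fused or bridged system of two rings. Going by these compounds alone, there, in this assay, cyano in place of hydrogen gives an at least 11-fold higher number from compound 3 to compound 4 (1.06 log units; beyond the scatter), so this position can move the read-out far towards lower toxicity in this test, which no step among compounds 1, 2 and 3 showed. Compound 4 has only a limit and not a number, so the full size of the step stays unknown: the limit of > 379000 nM in this assay, at which 1 of the 4 values shown sits.

The compounds shown leave open whether this large step belongs to cyano itself or would come with other groups at this position. An amine or a carboxylic acid at the same carbon would help to separate those two readings.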